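A few compounds are considered here, and "the series" means these few. Any claim that something is new, unique, unknown or untested is made for them only; others in the source may bear on it.

Compounds measured so far in a functional assay on the whole organism for inhibition, with Mus musculus as the target, in the writhing test, with stated times of 30 min and 3 h, at a dose of 25 mg/kg by the intraperitoneal route; a higher number here means more inhibition at the dose given (going by the name of the read-out), a lower number less inhibition:

Compound 1, `CCOC(=O)c1nn(-c2ccc(Cl)cc2)c(-c2ccc(OC)cc2OC)c1C`: 20%
Compound 2, `COc1ccc(-c2c(C)c(C(=O)O)nn2-c2ccc(Cl)cc2)c(OC)c1`: 20%

Among the compounds with values here, only one measured step exists, and it is small: no change at the digits printed from compound 1 to compound 2 (within the scatter). Compound 2 therefore stands level with compound 1 at the digits shown, with nothing to separate the two.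

Compound 3, `COc1ccc(-c2c(-c3ccccc3)c(C(=O)O)nn2-c2ccc(Cl)cc2)c(OC)c1`, differs from compound 2 by phenyl in place of methyl on an aromatic carbon.

Within the data shown here, no measured step bears on this change. Among the measured compounds shown here, the single step known concerns the carboxy group and leaves the ring carbon untouched, so it gives no guidance on swapping methyl for phenyl there. For the measured compounds named here, with no comparable step, the expectation rests on compound 2 alone, and a step of a number 5 percentage points higher from compound 2 to compound 3 (within the scatter) is expected, meaning no change beyond the scatter, with wide uncertainty. Compound 3 is accordingly estimated at 25%, within a range from 5% to 50%.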

Compound 3, a percentage reported as inhibition, in the whole organism at one dose (the size of the read-out at that dose, not a potency): 40%
Beside the measured number, compound 3's estimate is 15 percentage points below it; the measured number falls inside the stated range.
By their numbers in this assay, from the lowest: compounds 1 and 2 (each within the scatter of the next); then compound 3.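

In this assay, within the data shown here, the aromatic carbon that bears methyl in compound 2 proves sensitive to what sits on it: a number 20 percentage points higher from compound 2 to compound 3 (beyond the scatter) is the only measured step so far that lies beyond the scatter. Exchanging methyl for phenyl adds a whole six-membered aromatic ring at this place, and the series gains inhibition rather than losing it, so this carbon can carry the bigger group. Nothing measured here gives a reason for the rise.

Going by these compounds, what stays open is whether phenyl itself matters or whether other groups on this carbon would do the same, and an ethyl chain, a benzyl group or an amine would help to separate those possibilities. On these data alone, it is also open whether the ethyl ester would match the carboxy compound with phenyl in place, as it does with methyl.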